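The source may report more compounds than this note shows. Statements on the series, on what has been measured and on what is new or still open speak of the compounds shown alone.

Measured compounds in a functional assay on H4 cells for agonist activity at growth hormone secretagogue receptor type 1 (Homo sapiens), read by FLIPR; on this read-out higher numbers stand for an effect only at larger amounts of compound and lower numbers for an effect already at smaller amounts:
- compound 1, `CC(C)(N)C(=O)N[C@H](COCc1ccccc1)c1nnnn1CCCc1ccccc1`, gives 17 nM
- compound 2, `CN(c1ccccc1CCCn1nnnc1[C@@H](COCc1ccccc1)NC(=O)C(C)(C)N)S(C)(=O)=O`, gives 14 nM
- compound 3, `CC(C)(N)C(=O)N[C@H](COCc1ccccc1)c1nnn(Cc2ccc(NS(C)(=O)=O)cc2)n1`, gives 986 nM

Compound 3 stands highest of these three numbers in this assay, well beyond the scatter from both compound 1 and compound 2, whose two values lie within the scatter of each other. The next compound, compound 4 `CC(C)(N)C(=O)N[C@H](COCc1ccccc1)c1nnn(CC#N)n1`, differs from compound 3 in one place: cyano in place of 4-(methanesulfonamido)phenyl on a saturated chain carbon bound to an aromatic nitrogen. Within the data shown here, the only measured step, a 1.2-fold lower number from compound 1 to compound 2 (0.08 log units; within the scatter), concerns an addition on an aromatic carbon of the chain that compound 1 and compound 2 share, and it bears only loosely on a change that removes an aromatic ring altogether. Among the measured compounds shown here, no measured pair shows what replacing the whole substituent on the aromatic nitrogen by so small a group does. With the nearest guidance being the gap from compound 1 to compound 3, which tells only that this part of the molecule matters, compound 4 is expected to remain on the weaker side, with a step of about a 1.5-fold higher number from compound 3 to compound 4 (0.18 log units; within the scatter). The expected value for compound 4 in this assay is 1500 nM, within a range from 300 nM to 8000 nM.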

Compound 4, half-maximal effective concentration: 1520 nM
Compound 4: middle estimate off by 1.0-fold (0.01 log units), on the low side; the range from low to high includes it.
By their numbers in this assay, from the lowest: compounds 2 and 1 (each within the scatter of the next); then compounds 3 and 4 (each within the scatter of the next).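

In this assay, cyano in place of 4-(methanesulfonamido)phenyl on a saturated chain carbon bound to an aromatic nitrogen gives a 1.5-fold higher number from compound 3 to compound 4 (0.19 log units; within the scatter). This shows that, at this position, a group of 11 heavy atoms with a six-membered aromatic ring and a hydrogen-bond donor can give way to a group of 2 heavy atoms with no ring and no such donor, and the read-out stays within the scatter. Among these compounds, the earlier compounds did not show this, since the only step among them concerned an addition on an aromatic carbon, and no measurement here offers an explanation for the outcome.

The compounds shown leave open whether an amine or a carboxylic acid on the same saturated chain carbon would read like these two groups, and whether a plain phenyl without the methanesulfonamido group would do so. Also open, on these data alone, is how a longer chain ending in cyano would read in this assay, which would test whether the length of the substituent at this position counts for anything.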